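Para-Substituent Change on the Sulfonamide Aryl Ring

A few compounds are considered here, and "the series" means these few. Any claim that something is new, unique, unknown or untested is made for them only; others in the source may bear on it.

Three analogues sharing one core were tested in a functional assay on PANC-1 cells (Homo sapiens) for inhibition, read by MTT assay, with a stated time of 24 h, tested at 10 uM; a lower number here means less inhibition, a higher number more inhibition at the concentration tested (going by the name of the read-out). Compound 1 `CC(C)=CCC/C(C)=C/CC1Cc2c(OCCCNS(=O)(=O)c3ccc(C(F)(F)F)cc3)cc(=O)n(CCCO)c2CC1(C)C` gives 26.4%, compound 2 `CC(C)=CCC/C(C)=C/CC1Cc2c(OCCCNS(=O)(=O)c3ccc(Cl)cc3)cc(=O)n(CCCO)c2CC1(C)C` gives 14.5%, and compound 3 `CC(C)=CCC/C(C)=C/CC1Cc2c(OCCCNS(=O)(=O)c3ccc(Br)cc3)cc(=O)n(CCCO)c2CC1(C)C` gives 15.2%. Compound 3 thus stands second highest of the three, lying within the scatter of compound 2 and clearly below compound 1, as a number 11.2 percentage points lower from compound 1 to compound 3 (beyond the scatter) shows. Compound 4 `CC(C)=CCC/C(C)=C/CC1Cc2c(OCCCNS(=O)(=O)c3ccc([N+](=O)[O-])cc3)cc(=O)n(CCCO)c2CC1(C)C` carries the change (nitro in place of bromo on an aromatic carbon). Going by the values given here, no measured step exchanges a halogen for nitro; the nearest guide is a number 0.7 percentage points higher from compound 2 to compound 3 (within the scatter), while a number 11.9 percentage points lower from compound 1 to compound 2 (beyond the scatter) and a number 11.2 percentage points lower from compound 1 to compound 3 (beyond the scatter) show that a different para group can shift this assay by a modest amount. A step of a number 1.8 percentage points higher from compound 3 to compound 4 (within the scatter) is therefore expected, essentially none beyond the scatter. Compound 4 is estimated at 17%, within 5% to 32%.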

Compound 4, a percentage reported as inhibition, at one concentration (the size of the read-out at that concentration, not a potency): 7.4%
Compound 4: middle estimate off by 9.6 percentage points, on the high side, and the stated range covers the measured number.
By their numbers in this assay, from the lowest: compounds 4, 2 and 3 (each within the scatter of the next); then compound 1.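

In this assay, nitro joins chloro and bromo as a group the scatter does not separate, with a number 7.8 percentage points lower from compound 3 to compound 4 (within the scatter) and a number 7.1 percentage points lower from compound 2 to compound 4 (within the scatter) both printed at this position. Trifluoromethyl still stands apart from all three, and a number 19 percentage points lower from compound 1 to compound 4 (beyond the scatter) is the largest step seen here on this ring. Nothing given here explains why trifluoromethyl stands apart. On these data alone, whether an amine, a carboxylic acid or a methoxy group in this place would fall with compound 1 or with the other three stays open.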